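A few compounds are considered here, and "the series" means these few. Any claim that something is new, unique, unknown or untested is made for them only; others in the source may bear on it.

Working notes on the series. Two compounds carry numbers in a functional assay on HEK293 cells for antagonist activity at Voltage-dependent L-type calcium channel subunit alpha-1C (Oryctolagus cuniculus), read by FLIPR; on this read-out lower numbers stand for stronger inhibition and higher numbers for weaker inhibition. Compound 1 `CCOC(=O)C1=C(C)NC(COC(=O)c2ccccc2)=C(C(=O)OCC)C1c1cccc([N+](=O)[O-])c1` gives 210 nM in this assay. Compound 2 `COC(=O)C1=C(C)NC(C)=C(C(=O)OCCCl)C1c1cccc([N+](=O)[O-])c1` gives 26 nM in this assay, the lower of the two numbers; the gap to compound 1 lies beyond the scatter, so compound 2 stands as the stronger inhibitor of the pair. Among the compounds with values here, the two differ in more than one place, so no single step is read from them.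

Compound 3 `COC(=O)C1=C(C)NC(C)=C(C(=O)OCCOCc2ccccc2)C1c1cccc([N+](=O)[O-])c1` has not yet been measured. Against compound 2 the change is benzyloxy in place of chloro on a saturated chain carbon, two bonds along the chain from an oxygen next to a carbonyl group. Within the data shown here, no measured pair in the set shows this kind of exchange, so there is no step to lean on. The ester chain grows, the rest of the structure of compound 2 is kept. The expected step of a 1.3-fold higher number from compound 2 to compound 3 (0.13 log units; within the scatter) is small, in either direction, not beyond the scatter. For compound 3 the estimate in this assay is 35 nM, with a range from 10 nM to 120 nM.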

Compound 3, half-maximal inhibitory concentration: 9 nM
Compound 3: the middle estimate sits 3.9-fold (0.59 log units) above what was measured; the measured number lies below the stated range.
By their numbers in this assay, from the lowest: compound 3; then compound 2; then compound 1.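

Within the data shown here, this is the first single-place step: in this assay, benzyloxy in place of chloro on a saturated chain carbon, two bonds along the chain from an oxygen next to a carbonyl group, gives a 2.9-fold lower number from compound 2 to compound 3 (0.46 log units; beyond the scatter). The position therefore takes a group of 8 heavy atoms with a six-membered aromatic ring in place of a single chlorine, with no loss of inhibition and a modest gain. Nothing measured here explains the step.

The compounds shown leave open whether the step follows the aromatic ring or the oxygen of the benzyloxy group, a question that a phenyl group, a methoxy group or a longer alkyl chain on the same carbon would address. On these data alone, an amine or a carboxylic acid at this carbon also remains open, as does whether the step carries over to other ester groups on the shared core.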